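The source may hold more compounds than are shown below. What is called first, only, known or untested is meant among the compounds shown, and "the series" means these compounds.

Working notes on the series. In a functional assay on the whole organism for inhibition, with Scenedesmus acutus as the target, read by spectrophotometry, with a stated time of 48 h (on this read-out higher numbers stand for weaker inhibition and lower numbers for stronger inhibition), compound 1 `N#C/N=C/N=C(\N)N/N=C/c1ccc(Cl)cc1` gives 38000 nM. Compound 2 `N#C/N=C/N=C(\N)N/N=C/c1ccc(Cl)cc1F`, which carries the fluoro, gives 50100 nM in this assay; the step is a 1.3-fold higher number from compound 1 to compound 2 (0.12 log units; within the scatter). Compound 3 `NC1=NC=NC2=NC(c3ccc(Cl)cc3)NN12` gives 100000 nM in this assay, the highest of the three numbers; compound 2 stands nearest, within the scatter, and compound 1 furthest, beyond it. Compound 4 `NC1=NC=NC2=NC(c3ccc(Cl)cc3F)NN12` differs from compound 3 by fluoro in place of hydrogen on an aromatic carbon. Among the compounds with values here, the only measured step of this kind, a 1.3-fold higher number from compound 1 to compound 2 (0.12 log units; within the scatter), stayed within the scatter on the core of compound 1, so for compound 4 no step beyond the scatter is expected in this assay, leaning if anything toward a higher number. For compound 4 the expected step is a 1.2-fold higher number from compound 3 to compound 4 (0.08 log units; within the scatter). Compound 4 is therefore estimated at 120000 nM, with a range from 60000 nM to 250000 nM.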

Compound 4, half-maximal inhibitory concentration: 100000 nM
Beside the measured number, compound 4's estimate is 1.2-fold (0.08 log units) above it; the range from low to high includes it.
By their numbers in this assay, from the lowest: compounds 1, 2, 3 and 4 (each within the scatter of the next, the first and the last beyond it).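

On the core of compound 3, fluoro in place of hydrogen on an aromatic carbon, ortho to a large group and meta to a chloro group, gives in this assay a step of no change at the digits printed from compound 3 to compound 4 (within the scatter). This position therefore now shows a step within the scatter on a second core, and the two steps agree: the same change on two cores in this assay, a 1.3-fold higher number (0.12 log units; within the scatter) from compound 1 to compound 2 and no change at the digits printed (within the scatter) from compound 3 to compound 4, 1.3-fold (0.12 log units) apart, within the scatter of two such steps.

As far as these compounds go, whether an amine, a methoxy group or a carboxylic acid at this position would move the number in this assay beyond the scatter stays open. Also open, from the compounds shown here alone, is whether fluoro on the other aromatic carbons of this ring would behave in the same way.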